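This account rests on a few compounds, and the source may have more. Where it says the series, first, only, none or still open, it means among the compounds named here.

Compound 1 `O=C1CSc2cc(OCc3ccccc3)ccc2N1` was tested in an assay on isolated protein for inhibition of Amine oxidase [flavin-containing] B (Homo sapiens), read by fluorescence and spectrophotometry, with a stated time of 20 min (on this read-out higher numbers stand for weaker inhibition and lower numbers for stronger inhibition), where compound 1 gives 71 nM. Among the three measured compounds it stands second highest: compound 2 `O=C1CSc2cc(OCCCc3ccccc3)ccc2N1` gives 20 nM, while compound 3 `COc1ccc2c(c1)SCC(=O)N2` gives 42600 nM. For the measured compounds named here, the one step that bears on the benzyloxy part, the loss of the phenyl from compound 1 to compound 3, is a 600-fold higher number from compound 1 to compound 3 (2.78 log units; beyond the scatter); it shows how much that phenyl counts, but says nothing about a substituent on it. Compound 4 `O=C1CSc2cc(OCc3ccc(Br)cc3)ccc2N1` differs from compound 1 by bromo in place of hydrogen on an aromatic carbon. Going by the values given here, no measured step covers such an addition, so only a small step is expected, a 2.0-fold lower number from compound 1 to compound 4 (0.31 log units; beyond the scatter). Compound 4 is therefore estimated at 35 nM, within a range from 8 nM to 150 nM.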

Compound 4, half-maximal inhibitory concentration: 4.1 nM
Compound 4: the middle estimate sits 8.5-fold (0.93 log units) above what was measured; measured number below the stated range.
By their numbers in this assay, from the lowest: compound 4; then compound 2; then compound 1; then compound 3.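

With a bromo on an aromatic carbon of the outer phenyl ring, para to a large group, the change gives a 17-fold lower number from compound 1 to compound 4 (1.24 log units; beyond the scatter). The earlier compounds shown here showed only that this phenyl matters; this step shows that adding a single heavy atom to it can also change the number greatly. Nothing available explains the size of this step. On these data alone, whether chloro, methoxy or an amine at the same carbon would act like bromo remains open. Also open, as far as these compounds go, is what bromo would do at another carbon of that ring or on the longer chain of compound 2.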